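The source may report more compounds than this note shows. Statements on the series, on what has been measured and on what is new or still open speak of the compounds shown alone.

Compound 2 `N#Cc1c(Nc2cccc(C(F)(F)F)c2)nc(SCc2cn(Cc3ccccc3Cl)nn2)nc1-c1ccccc1` is one of two compounds tested in a functional assay on MGC-803 cells (Homo sapiens) for inhibition, read by MTT assay, with a stated time of 72 h; on this read-out higher numbers stand for weaker inhibition and lower numbers for stronger inhibition. In this assay, among the compounds with values here, compound 2 gives 22800 nM, and this is the only actual number among the two values shown. Compound 1 `C#CCSc1nc(Nc2ccc(Cl)cc2)c(C#N)c(-c2ccccc2)n1` reaches only a limit of the assay, > 128000 nM, rather than a number, so its result is known only as the limit of > 128000 nM in this assay, at which 1 of the 2 values shown sits. Compound 3 `N#Cc1c(Nc2ccccc2F)nc(SCc2cn(Cc3ccccc3Cl)nn2)nc1-c1ccccc1`, not yet measured, differs from compound 2 in a single place: 2-fluorophenyl in place of 3-(trifluoromethyl)phenyl on a nitrogen on an aromatic ring. Within the data shown here, no measured pair differs in just this way, so the size of the step cannot be read from the data. A change of this kind is expected to stay within the scatter or to weaken inhibition modestly. Compound 3 is therefore expected to give 35000 nM in this assay, within a range from 12000 nM to 110000 nM. That expectation amounts to an estimated step of a 1.5-fold higher number from compound 2 to compound 3 (0.19 log units; within the scatter).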

Compound 3, half-maximal inhibitory concentration: 7580 nM
Compound 3: middle estimate off by 4.6-fold (0.66 log units), on the high side, and the stated range ends above it.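

Swapping the group on this nitrogen changes the result: in this assay, the change to 2-fluorophenyl gives a 3.0-fold lower number from compound 2 to compound 3 (0.48 log units; beyond the scatter). Within the data shown here, this is the first step between measured compounds that differ in one place, so it shows that, with the rest of the molecule held fixed, the choice of group here alters inhibition of these cells. Compound 1 differs from compound 2 and compound 3 in more than one place and reaches only a limit of the assay, so it adds no comparison: the limit of > 128000 nM in this assay, at which 1 of the 3 values shown sits.

Among these compounds, the single step swaps both the substituent and its place on the phenyl ring, so the contribution of each remains unclear. From the compounds shown here alone, how a plain phenyl, a 3-fluorophenyl or a saturated cyclohexyl group on this nitrogen would compare also stays open.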